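The source may hold more compounds than are shown below. What is called first, only, known or untested is meant among the compounds shown, and "the series" means these compounds.

Two compounds share a core that carries a sulfonamide linker and a hydroxycarbamoyl group on a distant aromatic ring. Compound 1 `Cc1cc2cc(NS(=O)(=O)c3cc(C(=O)NO)ccc3Cl)ccc2n(C)c1=O` gives 32% in a functional assay on HL-60 cells (Homo sapiens) for antiproliferative activity, tested at 20 uM; on this read-out lower numbers stand for a weaker effect and higher numbers for a stronger effect at the one concentration tested. Compound 2 `COc1ccc(C(=O)NO)cc1CS(=O)(=O)Nc1ccc2c(c1)cc(C)c(=O)n2C` gives 0% in this assay, the lower of the two numbers, and compound 1 stands well above it, beyond the usual scatter of this kind of measurement. Among the measured compounds shown here, no single-change step connects these two measured compounds, so how much of that gap belongs to any one part of the structure cannot be told.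

Compound 3 `Cc1cc2cc(NS(=O)(=O)Cc3cccc(C(=O)NO)c3)ccc2n(C)c1=O` is the not yet measured neighbour of compound 2. The change is small: hydrogen in place of methoxy on an aromatic carbon The place is an aromatic carbon of a six-membered carbon-only ring, ortho to a large group and para to the hydroxycarbamoyl group. Since the measured pair gives no guidance on this particular change, the step from compound 2 to compound 3 in this assay is expected to be small, most likely none beyond the scatter, with a slight lean upward because compound 2 gives 0% and cannot go lower. Compound 3 is therefore expected to give about 8%, estimated between 0% and 30%, an expected step of a number 8 percentage points higher from compound 2 to compound 3 (within the scatter).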

Compound 3, a percentage reported as inhibition, at one concentration (the size of the read-out at that concentration, not a potency): 0%
Beside the measured number, compound 3's estimate is 8 percentage points above it; low and high end bracket the measured number.
By their numbers in this assay, from the lowest: compounds 2 and 3 (each within the scatter of the next); then compound 1.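

Tested in this assay, replacing methoxy with hydrogen on this aromatic carbon, ortho to a large group and para to the hydroxycarbamoyl group, gives no change at the digits printed from compound 2 to compound 3 (within the scatter). Among the compounds shown here, this is the first direct reading of a single change, and it shows that removing methoxy does not lift compound 2 from 0%, so on this core the methoxy group alone does not account for the empty read-out at the one concentration tested. No measurement shown here offers an explanation for this result.

Compound 2 and compound 3 both sit at the bottom of the scale, so any further loss of effect from a change at this carbon could not be seen, and the result says little about how much this position can matter on a compound with a measurable effect. Going by these compounds, it remains open whether a different group on this same carbon, such as an amine, a carboxylic acid or a longer chain like ethoxy, would bring the number in this assay up from the bottom of the scale.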